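Moving from a hydroxyphenyl to a chlorophenyl semicarbazide

This account rests on a few compounds, and the source may have more. Where it says the series, first, only, none or still open, it means among the compounds named here.

Measured compounds:
- compound 1: `COc1cc(NC(C)CCCNC(=O)Nc2ccc(C(F)(F)F)cc2)c2ncccc2c1`, 14000 nM
- compound 2: `COc1cc(NC(C)CCCNC(=O)NNC(=O)Nc2ccc(O)cc2)c2ncccc2c1`, 111000 nM

In a functional assay on CCRF-CEM cells (Homo sapiens) for inhibition, read by MTT assay, with a stated time of 72 h (a lower number here means a stronger inhibitor, a higher number a weaker inhibitor), compound 1 gives 14000 nM, and compound 2 gives 111000 nM, the higher of the two numbers shown. Going by the values given here, the single step between them, a 7.9-fold higher number from compound 1 to compound 2 (0.90 log units; beyond the scatter), is the only measured step in this set.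

Compound 3, `COc1cc(NC(C)CCCNC(=O)NNC(=O)Nc2cccc(Cl)c2)c2ncccc2c1`, keeps the semicarbazide arrangement of compound 2 and alters only the aryl group: 3-chlorophenyl in place of 4-hydroxyphenyl on an amide-type nitrogen. Among the compounds with values here, no measured pair isolates this kind of aryl swap on the semicarbazide; the step from compound 1 to compound 2 changed both the linker and the aryl group at once, so it bears on the present step only loosely. With compound 2 standing as the highest number measured, and compound 1 showing that a lower number is reachable in this series, a moderate move downward seems the most plausible expectation, with wide uncertainty.

Compound 3 is therefore expected to give about 50000 nM in this assay, within a range from 15000 nM to 160000 nM, which corresponds to an expected step of a 2.2-fold lower number from compound 2 to compound 3 (0.35 log units; beyond the scatter).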

Compound 3, half-maximal inhibitory concentration: 81000 nM
Beside the measured number, compound 3's estimate is 1.6-fold (0.21 log units) below it, within the range that was stated.
By their numbers in this assay, from the lowest: compound 1; then compounds 3 and 2 (each within the scatter of the next).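

With the semicarbazide held constant, this assay shows a 1.4-fold lower number from compound 2 to compound 3 (0.14 log units; within the scatter), so on this amide-type nitrogen's aryl side, 3-chlorophenyl and 4-hydroxyphenyl cannot be told apart, even though the counted hydrogen-bond donor and acceptor of the 4-hydroxyphenyl group are gone. The second comparison, a 5.8-fold higher number from compound 1 to compound 3 (0.76 log units; beyond the scatter), lies beyond the scatter, as does a 7.9-fold higher number from compound 1 to compound 2 (0.90 log units; beyond the scatter), so both semicarbazides shown sit apart from the urea compound 1, whichever of these two aryl groups they carry. No measurement shown gives a reason for either the flat aryl step or the gap to compound 1.

Compounds 1 to 3 leave open how much of that gap belongs to the semicarbazide and how much to the aryl group, since both differ in each step from compound 1, a question that a 4-(trifluoromethyl)phenyl group on the semicarbazide would address. On these data alone, it also remains open whether the flat response holds for quite different substituents on the phenyl ring, such as an amine or a carboxylic acid, or for a longer chain in the linker.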